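A few compounds are considered here, and "the series" means these few. Any claim that something is new, unique, unknown or untested is made for them only; others in the source may bear on it.

Measured in an ADME assay on HepG2 cells (Homo sapiens) for cytotoxicity, read by MTT assay, with a stated time of 72 h; on this read-out lower numbers stand for higher toxicity in this test and higher numbers for lower toxicity in this test:
- Compound 1 `O=[N+]([O-])c1cnc2c(Sc3ccc(Cl)cc3)cc(Cl)cn12`: > 7800 nM, a limit
- Compound 2 `O=[N+]([O-])c1c(CS(=O)(=O)C2CCCCC2)nc2c(Sc3ccc(Cl)cc3)cc(Cl)cn12`: > 31200 nM, a limit

Compound 2 stands at > 31200 nM, which is a limit of the assay and not a number. Compound 3 `O=[N+]([O-])c1c(CS(=O)(=O)c2cccnc2)nc2c(Sc3ccc(Cl)cc3)cc(Cl)cn12` carries pyridin-3-yl in place of cyclohexyl on a sulfonyl sulfur. For the measured compounds named here, the only measured step is a step that the two limits leave unreadable from compound 1 to compound 2, which installs (cyclohexylsulfonyl)methyl in place of hydrogen on an aromatic carbon. It bears on the change only loosely, so no shift beyond the scatter is expected in this assay. The expected step is a step that the limit leaves unreadable from compound 2 to compound 3. Compound 3 is estimated at 35000 nM, with an expected range from 12000 nM to 90000 nM.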

Compound 3, half-maximal cytotoxic concentration: > 31200 nM
Compound 3 was reported as a limit (the forecaster's own chance of this, stated with the estimate: 70%); the middle value is on the limit's open side.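

For the compounds shown here, compound 1, compound 2 and compound 3 all stand as limits of the assay, so no step among them can be read. The compounds shown leave open whether pyridin-3-yl and cyclohexyl on the sulfonyl sulfur differ at all.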